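Moving a Chloro Group Around the Shared Core

A few compounds are considered here, and "the series" means these few. Any claim that something is new, unique, unknown or untested is made for them only; others in the source may bear on it.

Among the compounds with values here, compound 1 `CC(C)Nc1nc(NCc2ccco2)c2ccccc2n1` is the only member of this small set that yields a plain number: in an ADME assay on J774.A1 cells (Mus musculus) for cytotoxicity, read by MTT assay, with a stated time of 72 h (a lower number here means that less compound is needed, a higher number that more compound is needed for the effect), compound 1 gives 17000 nM. Compound 2 `OCCNc1nc(NCc2ccco2)c2ccccc2n1` reaches only a limit of the assay, > 33000 nM. Compound 3 `CC(C)Nc1nc(NCc2ccco2)c2ccc(Cl)cc2n1` likewise stops at a limit, > 100000 nM. Measured as steps, there is an at least 1.9-fold higher number from compound 1 to compound 2 (0.28 log units; that floor lies within the scatter) and an at least 5.8-fold higher number from compound 1 to compound 3 (0.76 log units; beyond the scatter). Compound 4 `CC(C)Nc1nc(NCc2ccco2)c2cc(Cl)ccc2n1` is built from compound 1 by chloro in place of hydrogen on an aromatic carbon. The step from compound 1 to compound 3 is the one that bears on this change, since it also introduces chloro onto the shared core, and it was at least modest, as the limit of > 100000 nM in this assay, at which 1 of the 3 values shown sits, shows. A higher number for compound 4 is therefore expected, with a 3.5-fold higher number from compound 1 to compound 4 (0.55 log units; beyond the scatter) as the anticipated step. Compound 4 is estimated at 60000 nM, within 17000 nM to 150000 nM.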

Compound 4, half-maximal effective concentration: > 33000 nM
Compound 4: no number, only a limit; the forecaster's own chance of this, stated with the estimate: 55%; the middle value does not contradict the limit.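

Placing chloro on the aromatic carbon that is meta to a fused ring and para to a fused ring gives an at least 1.9-fold higher number from compound 1 to compound 4 (0.28 log units; that floor lies within the scatter), so at this position the change is not shown to exceed the scatter, whereas the chloro change in compound 3 was. Compound 4 stops at a limit of the assay, not a number: the limit of > 33000 nM in this assay, at which 2 of the 4 values shown sit. Compounds 3 and 4 both give only limits, and no order between the two chloro positions can be read.

On these data alone, how far compound 4 truly lies from compound 1 stays open. So does whether an amine or a methoxy group at this position would give a plain number in this assay.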